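The source may hold more compounds than are shown below. What is called first, only, known or untested is meant among the compounds shown, and "the series" means these compounds.

Measured compounds:
Compound 1, `CCOC(=O)c1cnc2scc(-c3cccc(C)c3)n12`, in an assay on isolated protein for inhibition of Indoleamine 2,3-dioxygenase 1 (Homo sapiens), with a stated time of 30 min (on this read-out lower numbers stand for stronger inhibition and higher numbers for weaker inhibition), gives > 100000 nM, which is a limit of the assay.
Compound 2, `CCOC(=O)c1cnc2scc(-c3ccccc3)n12`, in this assay gives > 100000 nM, again a limit.
Compound 3, `CCOC(=O)c1cnc2scc(-c3ccccc3C)n12`, in this assay gives > 100000 nM, also a limit.

Compound 2 stands at the limit of this assay, and the two further values shown sit at the same limit, as noted in the limit of > 100000 nM in this assay, at which 3 of the 3 values shown sit. The step that the two limits leave unreadable from compound 1 to compound 2 and the step that the two limits leave unreadable from compound 2 to compound 3 cannot be sized, because both ends are limits.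

Compound 4, `CCOC(=O)c1cnc2scc(-c3ccc(OC)cc3)n12`, differs from compound 2 by methoxy in place of hydrogen on an aromatic carbon. Among the compounds with values here, the measured steps that bear on it are the two ring substitutions above, and neither gives a readable size; they show only that a methyl group at two positions of the six-membered ring leaves the read-out at the limit. Within the data shown here, no step shows a gain from a ring substituent. Compound 4 is therefore expected to stay at or near the limit, with the step that the limit leaves unreadable from compound 2 to compound 4 expected to be none beyond the scatter. The estimate for compound 4 in this assay is 150000 nM, within 30000 nM to 1000000 nM.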

Compound 4, half-maximal inhibitory concentration: 56000 nM
Compound 4: middle estimate off by 2.7-fold (0.43 log units), on the high side, and the stated range covers the measured number.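

Methoxy on the six-membered aromatic ring, para to a large group, gives the first read-out in this assay that is a number and not a limit, with compound 4 at 56000 nM. The change reads as an at least 1.7-fold lower number from compound 2 to compound 4 (0.25 log units; that floor lies within the scatter), so the series now has a measurable value, but a gain beyond the scatter is not established. The steps among compound 1, compound 2 and compound 3 cannot be read, and compound 4 alone stands off the limit: the limit of > 100000 nM in this assay, at which 3 of the 4 values shown sit.

Open, going by these compounds, is whether methoxy at the other ring positions, or a hydroxyl, an amine or a carboxylic acid at this one, would give a lower number. Also open, on these data alone, is whether this value holds when the ethyl ester of the shared core gives way to a carboxylic acid or an amide.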